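Benzylic ether variants in one series: outlook for compound 4

The source may report more compounds than this note shows. Statements on the series, on what has been measured and on what is new or still open speak of the compounds shown alone.

Three compounds have been run in a functional assay on MIA PaCa-2 cells (Homo sapiens) for inhibition, read by MTT assay, with a stated time of 48 h, tested at 10 uM; on this read-out higher numbers stand for more inhibition of growth at the one concentration tested and lower numbers for less inhibition of growth:

Compound 1 `COc1ccc(COc2cc(O)c3c(=O)cc(C)oc3c2[C@H]2CCN(C)C[C@H]2O)cc1`: 15%
Compound 2 `Cc1cc(=O)c2c(O)cc(OCc3ccc(Br)cc3)c([C@H]3CCN(C)C[C@H]3O)c2o1`: 13%
Compound 3 `Cc1cc(=O)c2c(O)cc(OCc3ccc([N+](=O)[O-])cc3)c([C@H]3CCN(C)C[C@H]3O)c2o1`: 12%

Compound 3 holds the lowest of the three numbers, but its distance to the others is small: a number 3 percentage points lower from compound 1 to compound 3 (within the scatter) and a number 1 percentage points lower from compound 2 to compound 3 (within the scatter) both fall within the scatter, as does a number 2 percentage points lower from compound 1 to compound 2 (within the scatter). On these numbers the three compounds cannot be placed in any order.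

Compound 4 `Cc1cc(=O)c2c(O)cc(OC/C=C/c3ccccc3)c([C@H]3CCN(C)C[C@H]3O)c2o1` has not been measured. It differs from compound 3 by 2-phenylethenyl in place of 4-nitrophenyl on a saturated chain carbon bound to an oxygen on an aromatic ring. Going by the values given here, none of the measured steps bears on this change directly: they all swap one group on the aromatic ring for another, whereas here the whole 4-nitrophenyl gives way to 2-phenylethenyl. Among the compounds with values here, the only guidance is that every variation so far has left the read-out at a similar level, so no step beyond the scatter is expected here either.

Compound 4 is therefore expected to give about 14% in this assay, within 4% to 26%. The step from compound 3 this estimate implies is a number 2 percentage points higher from compound 3 to compound 4 (within the scatter).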

Compound 4, percent growth inhibition at one concentration: 11%
Compound 4: middle estimate off by 3 percentage points, on the high side, within the range that was stated.
By their numbers in this assay, from the lowest: compounds 4, 3, 2 and 1 (each within the scatter of the next).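

In this assay, going by these compounds alone, the earlier steps only swapped one group on the aromatic ring for another, whereas here the change reaches the chain itself, and the read-out still holds: a number 1 percentage points lower from compound 3 to compound 4 (within the scatter), a number 2 percentage points lower from compound 2 to compound 4 (within the scatter) and a number 4 percentage points lower from compound 1 to compound 4 (within the scatter). 2-Phenylethenyl on a saturated chain carbon bound to an oxygen on an aromatic ring thus reads the same as 4-nitrophenyl, 4-bromophenyl and 4-methoxyphenyl, and the four compounds still cannot be placed in any order. No measurement at hand accounts for this flat read-out.

Going by these compounds, all four compounds keep an aromatic ring on this chain, so it stays open whether a group without one, such as an amine, a carboxylic acid or a plain longer alkyl chain, would move the number beyond the scatter. Also open, on these data alone, is how the compounds would compare at any concentration other than the single one tested.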